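Shortening the chain and capping the amine with methyl

The compounds below may be only part of what the source reports. "The series", "measured", "known", "first", "only" and "open" are said of these compounds alone.

Measured compounds:
Compound 1, `O=S(=O)(NCCCCNCc1ccc(Br)cc1)c1cc(C(F)(F)F)cc(C(F)(F)F)c1`, 2100 nM
Compound 2, `O=[N+]([O-])c1ccc(S(=O)(=O)NCCCCCCNCc2ccc(Br)cc2)cc1`, 9800 nM

Both compounds were tested in a functional assay on MIA PaCa-2 cells (Homo sapiens) for inhibition, read by MTT assay, with a stated time of 72 h; on this read-out lower numbers stand for stronger inhibition of growth and higher numbers for weaker inhibition of growth. Compound 1 gives 2100 nM, the lower of the two numbers, and compound 2 gives 9800 nM, a gap that lies beyond the usual scatter of repeated measurements. Compound 1 and compound 2 differ in more than one place, so the two values can only be read side by side, without pointing to a single cause.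

Compound 3, `CN(CCCNS(=O)(=O)c1cc(C(F)(F)F)cc(C(F)(F)F)c1)Cc1ccccc1`, has not yet been measured. It differs from compound 1 in one region: benzyl(methyl)amino in place of ((4-bromobenzyl)amino)methyl on a saturated chain carbon, three bonds along the chain from a sulfonamide nitrogen. In plain terms, the chain between the sulfonamide nitrogen and the amine is one carbon shorter, the amine now carries a methyl group and so has lost its hydrogen, and the benzyl group no longer carries a bromine. Among the measured compounds shown here, no measured pair here isolates any of these three changes, so the direction of the step rests on judgement alone. A modest move toward weaker inhibition of growth, around the edge of the scatter, is expected, giving a step of a 2.4-fold higher number from compound 1 to compound 3 (0.38 log units; beyond the scatter). Compound 3 is estimated at 5000 nM, with a range of 1500 nM to 16000 nM.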

Compound 3, concentration for 50% growth inhibition: 33000 nM
For compound 3 the middle estimate is 6.6-fold (0.82 log units) below the measured one, outside the stated range (above it).
By their numbers in this assay, from the lowest: compound 1; then compound 2; then compound 3.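

In this assay, replacing ((4-bromobenzyl)amino)methyl with benzyl(methyl)amino on a saturated chain carbon, three bonds along the chain from a sulfonamide nitrogen, gives a 16-fold higher number from compound 1 to compound 3 (1.20 log units; beyond the scatter), a large move toward weaker inhibition of growth. The earlier pair could only be read side by side, whereas this step keeps the sulfonamide end of compound 1 unchanged and shows that growth inhibition depends strongly on this one region, where the entering group has no hydrogen-bond donor and no bromine. Nothing available here explains the size of this step.

The step joins three changes, namely the shorter chain, the methyl on the amine and the missing bromine, and no compound shown alters one of them alone, so their separate shares remain open. Also open, going by these compounds, is what a chlorine in place of the bromine, or an ethyl group in place of the methyl on the amine, would do to the number.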